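The source may report more compounds than this note shows. Statements on the series, on what has been measured and on what is new or still open speak of the compounds shown alone.

Compound 1 `COc1ccc(C(=O)O)cc1-c1cccc(COc2ccc3c(c2)CN(C2CCCC2)C3=O)c1`: 30%
Compound 2 `O=C(O)c1cc(F)cc(-c2cccc(COc3ccc4c(c3)CN(C3CCCC3)C4=O)c2)c1`: 55%

Both values come from an ADME assay on microsomes from liver (Rattus norvegicus) for metabolic stability, read by LC-MS, with a stated time of 1 h, at 37 degrees C, tested at 4 uM (on this read-out higher numbers stand for a more stable compound and lower numbers for a less stable compound), and compound 2 stands highest of the two. Compound 3 `Cc1ccc(C(=O)O)cc1-c1cccc(COc2ccc3c(c2)CN(C2CCCC2)C3=O)c1` has not yet been measured. It keeps the shared core and differs from compound 2 in one group: 5-carboxy-2-methylphenyl in place of 3-carboxy-5-fluorophenyl on an aromatic carbon. Within the data shown here, the only measured step that bears on this change is a number 25 percentage points higher from compound 1 to compound 2 (beyond the scatter), a modest step beyond the scatter. Among the measured compounds shown here, that step replaced 5-carboxy-2-methoxyphenyl with 3-carboxy-5-fluorophenyl, and compound 3 returns to a group that differs by name from the one in compound 1 only in having methyl for methoxy. No measurement isolates the methyl group, so the reasoning rests on compound 1 alone, at 30%. Part of the gain is therefore expected to be lost, giving an estimated a number 15 percentage points lower from compound 2 to compound 3 (beyond the scatter). Compound 3 is expected at 40%, within an estimated range of 22% to 60%.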

Compound 3, percent of the compound remaining: 2%
Compound 3: middle estimate off by 38 percentage points, on the high side; measured number below the stated range.
By their numbers in this assay, from the lowest: compound 3; then compound 1; then compound 2.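

In this assay the 5-carboxy-2-methylphenyl group brought a number 53 percentage points lower from compound 2 to compound 3 (beyond the scatter) and so did not land partway back towards compound 1, as the earlier pair alone might have suggested. Methyl in place of methoxy gave a number 28 percentage points lower from compound 1 to compound 3 (beyond the scatter) and thus shows that this one substituent on the ring matters by itself, with compound 3 the least stable of the three. The data offer nothing that explains why the methyl group has this effect.

Compound 2 differs from compound 3 in both the substituent and the placing of the carboxylic acid, so the shares of these two changes in the large drop remain unseparated. Going by these compounds, it also remains open whether a chlorine atom or a trifluoromethyl group in the place of the methyl would follow the methyl or the methoxy compound.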